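Isopropyl on the amidine nitrogen across two benzofuran cores

The compounds below may be only part of what the source reports. "The series", "measured", "known", "first", "only" and "open" are said of these compounds alone.

Measured so far:
compound 1 `N=C(N)c1ccc2oc(-c3cccc(OCCCOc4ccccc4)c3)cc2c1` gives 10300 nM in an ADME assay on L6 cells (Rattus norvegicus) for cytotoxicity, read by resazurin assay, with a stated time of 70 h; a lower number here means a stronger inhibitor, a higher number a weaker inhibitor
compound 2 `CC(C)NC(=N)c1ccc2oc(-c3cccc(OCCCOc4ccccc4)c3)cc2c1` gives 26500 nM in this assay
compound 3 `N=C(N)c1ccc2cc(-c3ccc(OCCCCCOc4ccccc4)cc3)oc2c1` gives 9000 nM in this assay

Compound 1 and compound 2 share a core and differ in one place: isopropyl in place of hydrogen on an amine nitrogen. That change gave a 2.6-fold higher number from compound 1 to compound 2 (0.41 log units; beyond the scatter), a modest step, but beyond the scatter.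

Compound 3 has a different core; how the core of compound 3 differs from the core of compound 1 is not broken down here. In this assay compound 3 and compound 1 stand within the scatter of each other, while compound 2 gives the highest number of the three.

Compound 4 `CC(C)NC(=N)c1ccc2cc(-c3ccc(OCCCCCOc4ccccc4)cc3)oc2c1` is not yet measured. It differs from compound 3 by isopropyl in place of hydrogen on an amine nitrogen, and the place of the change reads the same, word for word, as for compound 1 and compound 2, so this is the same change on a second core. Going by the values given here, only one earlier instance exists, so the expectation rests on a single step.

The expected step from compound 3 to compound 4 in this assay is a 2.4-fold higher number from compound 3 to compound 4 (0.39 log units; beyond the scatter), because of a 2.6-fold higher number from compound 1 to compound 2 (0.41 log units; beyond the scatter) on the other core. Compound 4 is therefore estimated at 22000 nM, expected to lie between 11000 nM and 45000 nM.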

Compound 4, half-maximal inhibitory concentration: 10700 nM
Beside the measured number, compound 4's estimate is 2.1-fold (0.31 log units) above it; measured number below the stated range.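

In this assay, going by these compounds alone, isopropyl in place of hydrogen on the amine nitrogen gives a 1.2-fold higher number from compound 3 to compound 4 (0.08 log units; within the scatter), so on this core the change leaves no step that can be told from the scatter. Set side by side, the two steps cannot be told apart: the same change on two cores in this assay, a 2.6-fold higher number (0.41 log units; beyond the scatter) from compound 1 to compound 2 and a 1.2-fold higher number (0.08 log units; within the scatter) from compound 3 to compound 4, 2.2-fold (0.34 log units) apart, within the scatter of two such steps

The result therefore fits one modest step shared by both cores, and it equally fits a step present on the core of compound 1 alone; it does not show that the core decides the size of the step, nor that the step is constant, as each core rests on a single pair.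

Still open, from the compounds shown here alone, is whether methyl, cyclopentyl or another group on the same nitrogen would give a step beyond the scatter on both cores. Also open is how the step behaves with a chain of another length, since the two cores shown differ in more than one place.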